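A few compounds are considered here, and "the series" means these few. Any claim that something is new, unique, unknown or untested is made for them only; others in the source may bear on it.

Compound 1 `O=S(=O)(c1cc(Cl)cc(Cl)c1)c1cnc2cc(F)ccc2c1-c1ccccc1F` is the starting point of this comparison. In an ADME assay on microsomes from liver (Homo sapiens) for metabolic stability, tested at 2.5 uM (on this read-out higher numbers stand for fast clearance and lower numbers for slow clearance), compound 1 gives 0.93 mL/min, the lowest of the three numbers in hand. Its nearest neighbour is compound 3 `N#Cc1cccc(S(=O)(=O)c2cnc3cc(F)ccc3c2-c2ccccc2F)c1`, which in this assay gives 1.39 mL/min; the change a 1.5-fold higher number from compound 1 to compound 3 (0.17 log units; within the scatter) falls within the scatter, so the two cannot be told apart. The furthest is compound 2 `COc1cccc(S(=O)(=O)c2cnc3cc(F)ccc3c2-c2cccc(F)c2)c1`, which differs from the starting compound in two places; in this assay compound 2 gives 3.36 mL/min, a number beyond the scatter from the starting compound.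

Compound 4 `COc1cccc(-c2c(S(=O)(=O)c3cc(Cl)cc(Cl)c3)cnc3cc(F)ccc23)c1` has not yet been measured. It differs from compound 1 as follows: 3-methoxyphenyl in place of 2-fluorophenyl on an aromatic carbon. Going by the values given here, no measured step bears directly on this change: the only single-point step in hand exchanges the group on the sulfonyl sulfur, and it stayed within the scatter. Among the compounds with values here, compound 2, the one measured compound that carries a 3-methoxyphenyl, differs from compound 1 in two places, so its higher number cannot be assigned to either change alone.

On this basis compound 4 is expected to land a 1.7-fold higher number from compound 1 to compound 4 (0.24 log units; within the scatter), a small rise that may well stay within the scatter, with an estimated value of 1.6 mL/min, most likely between 0.7 mL/min and 3.5 mL/min.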

Compound 4, intrinsic clearance in a liver preparation (reported as CLH), per the amount of preparation that the assay uses: 1.51 mL/min
The estimate for compound 4 lay 1.1-fold (0.03 log units) above the measured number; the range from low to high includes it.
By their numbers in this assay, from the lowest: compounds 1, 3 and 4 (each within the scatter of the next); then compound 2.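

In this assay, the aromatic carbon opposite the ring nitrogen now has its first single-change reading, a 1.6-fold higher number from compound 1 to compound 4 (0.21 log units; within the scatter), with 3-methoxyphenyl in place of 2-fluorophenyl. Going by these compounds alone, the earlier compounds showed only that an exchange on the sulfonyl sulfur, a 1.5-fold higher number from compound 1 to compound 3 (0.17 log units; within the scatter), stayed within the scatter; this result shows that a change at the aromatic carbon also leaves compound 4 indistinguishable from compound 1, even though the entering group brings a hydrogen-bond acceptor that the leaving group lacks. No measurement in hand offers an explanation for this outcome.

The compounds shown leave open whether this position tolerates anything other than a substituted phenyl, such as a small amine, a carboxylic acid or a longer alkyl chain, and whether moving the methoxy elsewhere on the ring would give a step beyond the scatter. Within the data shown here, they also leave open whether 3-methoxyphenyl at this carbon would give a similar reading alongside 3-cyanophenyl on the sulfonyl sulfur, as no compound here combines the two.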